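Two cores, one phenyl swap carried across

The source may report more compounds than this note shows. Statements on the series, on what has been measured and on what is new or still open speak of the compounds shown alone.

Compound 1 `Cc1ccc(CS(=O)(=O)/C(=C/c2cccc(Cl)c2Cl)C(=O)c2ccc(Cl)cc2)cc1` and compound 2 `Cc1ccc(CS(=O)(=O)/C(=C/c2ccccc2Br)C(=O)c2ccc(Cl)cc2)cc1` share one core; compound 3 `Cc1ccc(CS/C(=C/c2ccccc2Br)C(=O)c2ccc(Cl)cc2)cc1` and the unmeasured compound 4 `Cc1ccc(CS/C(=C/c2cccc(Cl)c2Cl)C(=O)c2ccc(Cl)cc2)cc1` share another. In a functional assay on DU-145 cells (Homo sapiens) for inhibition, read by trypan blue exclusion, with a stated time of 96 h (a higher number here means a weaker inhibitor of growth, a lower number a stronger inhibitor of growth), compound 2 gives 25000 nM, and compound 1 gives 1000 nM. Within the data shown here, the one change between them, (2,3-dichlorophenyl in place of 2-bromophenyl on a double-bonded chain carbon bound to a double-bonded chain carbon), produced a 25-fold lower number from compound 2 to compound 1 (1.40 log units; beyond the scatter). In this assay compound 3 gives 10000 nM, which sits beyond the scatter from both of the others. The difference between the core of compound 3 and the core of compound 2 is not broken down here.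

Compound 4 is compound 3 carrying the same change, (2,3-dichlorophenyl in place of 2-bromophenyl on a double-bonded chain carbon bound to a double-bonded chain carbon), at the same place word for word, so the two steps are the same kind of change on different cores. Among the measured compounds shown here, whether the second core carries this change as fully as the first did is not known from two cores alone, and the values of compound 2 and compound 3 show only that the cores themselves are not far apart in this assay. The expected step from compound 3 to compound 4 is therefore placed beside the earlier one, with some allowance for it falling short: a 20-fold lower number from compound 3 to compound 4 (1.30 log units; beyond the scatter) is the estimate, resting on a 25-fold lower number from compound 2 to compound 1 (1.40 log units; beyond the scatter) and on compound 3 at 10000 nM. For compound 4 in this assay the estimate is 500 nM, expected to lie between 150 nM and 2500 nM.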

Compound 4, concentration for 50% growth inhibition: 25000 nM
The estimate for compound 4 lay 50-fold (1.70 log units) below the measured number, outside the stated range (above it).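

In this assay, 2,3-dichlorophenyl in place of 2-bromophenyl gave a 2.5-fold higher number from compound 3 to compound 4 (0.40 log units; beyond the scatter). Set beside the earlier step on the other core, the same change runs in the opposite direction, so its effect on the core of compound 1 cannot be taken as a guide to its effect on the core of compound 4: the same change on two cores in this assay, a 25-fold lower number (1.40 log units; beyond the scatter) from compound 2 to compound 1 and a 2.5-fold higher number (0.40 log units; beyond the scatter) from compound 3 to compound 4, 63-fold (1.80 log units) apart, beyond the scatter of two such steps This shows that, for these four compounds, the outcome of the change depends on the core that carries it, but it does not show which feature of the two cores is responsible, and with only two compounds on each core it gives no general rule for other phenyl groups in this series.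

Going by these compounds, it remains open whether the reversal is particular to this pair of halogenated phenyl groups, or whether a phenyl carrying an amine or a carboxylic acid in place of the halogens would also respond differently on the two cores. A sulfoxide in the chain is a further open case, as the compounds shown do not indicate whether it would follow the core of compound 1 or the core of compound 3.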